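The source may hold more compounds than are shown below. What is called first, only, known or untested is meant among the compounds shown, and "the series" means these compounds.

Compound 1, with the structure `O=C1Nc2ccc(C(=O)c3ccco3)cc2/C1=C/c1cc(F)c(O)c(Br)c1`, and compound 2, with the structure `O=C1Nc2ccc(C(=O)c3ccco3)cc2/C1=C/c1ccnc(Cl)c1`, share one core and differ only in the aryl ring hung on the double-bonded chain carbon. In an assay on HeLa cells for inhibition of Kinesin-like protein KIF15 (Homo sapiens), read by microscopy, with stated times of 2 s and 20 s, tested at 750 nM (a higher number here means more inhibition at the concentration tested (going by the name of the read-out), a lower number less inhibition), compound 1 gives 38%, while compound 2 gives 15.8%. Compound 2 therefore stands at the lower of the two numbers, set apart from compound 1 by the step of a number 22.2 percentage points lower from compound 1 to compound 2 (beyond the scatter), which swaps the whole ring.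

Compound 3, with the structure `O=C1Nc2ccc(C(=O)c3ccco3)cc2/C1=C/c1ccncc1`, has not yet been measured. Relative to compound 2 the change is hydrogen in place of chloro on an aromatic carbon. Going by the values given here, no measured step touches a single substituent on this ring; the one known step exchanged the entire aryl group, so it speaks only loosely to this smaller change. Given that, the step from compound 2 to compound 3 is expected to be a number 3.8 percentage points lower from compound 2 to compound 3 (within the scatter), within the scatter. Compound 3 is accordingly estimated to give 12%, with a range from 0% to 30%.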

Compound 3, a percentage reported as inhibition, at one concentration (the size of the read-out at that concentration, not a potency): 0.8%
Estimate against measurement, compound 3: 11.2 percentage points above; the measured number falls inside the stated range.
By their numbers in this assay, from the lowest: compound 3; then compound 2; then compound 1.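

In this assay the chloro next to the ring nitrogen now has a step of its own: going from 2-chloropyridin-4-yl to pyridin-4-yl gives a number 15 percentage points lower from compound 2 to compound 3 (beyond the scatter) and shows that this single atom matters, which the earlier exchange of the whole ring could not separate out. Measured against the bromo, fluoro and hydroxy-bearing ring, the bare pyridin-4-yl gives a number 37.2 percentage points lower from compound 1 to compound 3 (beyond the scatter) and stands lowest of the three, with compound 3 at 0.8% and so almost no inhibition left. No independent evidence bears on why the chloro has this effect.

On these data alone, whether an amine or a methoxy group on this same carbon would give a number nearer that of compound 2 or that of compound 3 remains open. Also open, as far as these compounds go, is how much of the gap to compound 1 comes from the ring nitrogen and how much from the ring's substituents.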